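A few compounds are considered here, and "the series" means these few. Any claim that something is new, unique, unknown or untested is made for them only; others in the source may bear on it.

Measured so far in a functional assay on HepG2 cells (Homo sapiens) for inhibition, read by MTT assay, with a stated time of 72 h; a higher number here means a weaker inhibitor, a lower number a stronger inhibitor:
Compound 1 `COc1ccc(-n2cc(COc3cccc(NC(=O)Nc4ccc(Cl)c(C(F)(F)F)c4)c3)nn2)cc1` gives 4680 nM.
Compound 2 `Cc1ccc(-n2cc(COc3cccc(NC(=O)Nc4ccc(Cl)c(C(F)(F)F)c4)c3)nn2)cc1` gives 5430 nM.
Compound 3 `CC(C)c1cccc(-n2cc(COc3cccc(NC(=O)Nc4ccc(Cl)c(C(F)(F)F)c4)c3)nn2)c1` gives 3250 nM.

Compound 3 carries the lowest of the three numbers, but its separation from the other two is small: a 1.4-fold lower number from compound 1 to compound 3 (0.16 log units; within the scatter) and a 1.7-fold lower number from compound 2 to compound 3 (0.22 log units; within the scatter), both within the scatter, as is a 1.2-fold higher number from compound 1 to compound 2 (0.06 log units; within the scatter). On these numbers the three compounds cannot be told apart, and compound 3 is not to be called the strongest of them.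

Compound 4 `O=C(Nc1cccc(OCc2cn(-c3ccccc3F)nn2)c1)Nc1ccc(Cl)c(C(F)(F)F)c1` differs from compound 3 in one place: 2-fluorophenyl in place of 3-isopropylphenyl on an aromatic nitrogen. The measured steps that bear on this change are the two that likewise exchange the group on that aromatic nitrogen, namely a 1.4-fold lower number from compound 1 to compound 3 (0.16 log units; within the scatter) and a 1.7-fold lower number from compound 2 to compound 3 (0.22 log units; within the scatter). Neither exchange moved the number in this assay beyond the scatter, and the exchange between a methoxy and a methyl on that group, a 1.2-fold higher number from compound 1 to compound 2 (0.06 log units; within the scatter), was equally flat. For the measured compounds named here, no measured step involves a 2-fluorophenyl, so the expectation rests on the flatness of the exchanges seen so far. In this assay no step beyond the scatter is expected in either direction.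

Compound 4 is therefore expected to give 4500 nM in this assay, with a range of 1800 nM to 12000 nM. The estimated step is a 1.4-fold higher number from compound 3 to compound 4 (0.14 log units; within the scatter), within the scatter.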

Compound 4, half-maximal inhibitory concentration: 1520 nM
Beside the measured number, compound 4's estimate is 3.0-fold (0.47 log units) above it; the measured number lies below the stated range.
By their numbers in this assay, from the lowest: compound 4; then compounds 3, 1 and 2 (each within the scatter of the next).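

In this assay the group on the aromatic nitrogen of the five-membered ring turns out not to be silent: 2-fluorophenyl gives a 2.1-fold lower number from compound 3 to compound 4 (0.33 log units; beyond the scatter) and a 3.1-fold lower number from compound 1 to compound 4 (0.49 log units; beyond the scatter) and a 3.6-fold lower number from compound 2 to compound 4 (0.55 log units; beyond the scatter), all modest but all beyond the scatter, whereas the exchanges among the three earlier groups stayed within it. Compound 4 is the only compound shown with fluorine on this ring and the only one with a substituent two ring bonds from the ring nitrogen by way of that aryl group's first carbon, so a single compound cannot separate the contribution of the fluorine from that of its place on the ring or from the loss of the 3-isopropyl, 4-methyl and 4-methoxy groups. For the compounds shown here, nothing available explains the drop in the number, and the series so far supplies only this cell read-out.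

Unsubstituted phenyl, 3-fluorophenyl, 4-fluorophenyl and 2-chlorophenyl on the same nitrogen would show whether the step follows the fluorine, its place or neither. From the compounds shown here alone, whether the position also accepts a basic amine, a carboxylic acid or a longer alkyl chain in place of the aryl group stays open.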